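The compounds below may be only part of what the source reports. "The series", "measured", "known", "first", "only" and "open" are said of these compounds alone.

For the measured compounds named here, in a functional assay on HL-60 cells (Homo sapiens) for cytotoxicity, read by WST assay, with a stated time of 48 h (on this read-out higher numbers stand for an effect only at larger amounts of compound and lower numbers for an effect already at smaller amounts), compound 2 `O=C1OC[C@H](Cc2ccccc2)[C@H]1Cc1cccc(F)c1` gives 75000 nM, the only actual number so far. Compound 1 `O=C1OC[C@H](Cc2ccccc2)[C@H]1Cc1cccc(O)c1` stands at > 100000 nM, which is a limit. Going by the values given here, one measured step bears on what follows: an at least 1.3-fold lower number from compound 1 to compound 2 (0.12 log units; that floor lies within the scatter), with fluoro in place of hydroxy on an aromatic carbon. Compound 3 `O=C1OC[C@H](Cc2ccccc2)[C@H]1Cc1ccc(O)cc1` differs from compound 2 by 4-hydroxyphenyl in place of 3-fluorophenyl on a saturated chain carbon bound to a saturated ring carbon, with 4-hydroxyphenyl in place of 3-fluorophenyl. Read in reverse, that single step suggests only a slight move toward higher numbers, and a result at the limit would be no surprise. The expected change is a 1.3-fold higher number from compound 2 to compound 3 (0.12 log units; within the scatter). For compound 3 the estimated value is 100000 nM, within a range of 45000 nM to 220000 nM.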

Compound 3, half-maximal effective concentration: 88000 nM
The estimate for compound 3 lay 1.1-fold (0.06 log units) above the measured number; measured number inside the range.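

In this assay, the place on a saturated chain carbon bound to a saturated ring carbon takes 4-hydroxyphenyl in place of 3-fluorophenyl with a 1.2-fold higher number from compound 2 to compound 3 (0.07 log units; within the scatter), so this change separates neither compound from the other. With 4-hydroxyphenyl in place of 3-hydroxyphenyl, the result is an at least 1.1-fold lower number from compound 1 to compound 3 (0.05 log units; that floor lies within the scatter), and only that floor can be read. The value of compound 1 is a limit: the limit of > 100000 nM in this assay, at which 1 of the 3 values shown sits.

Going by these compounds, it remains open whether an amine or a carboxylic acid on this phenyl ring would give a clearly lower number. Whether any group at this place moves the number beyond the scatter also stays unresolved.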